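This account rests on a few compounds, and the source may have more. Where it says the series, first, only, none or still open, it means among the compounds named here.

Working notes on the series. Compound 1 `CC1(Cc2ccc([N+](=O)[O-])cc2)CC(S(=O)(=O)c2ccc(F)cc2)=C(c2ccc(/C(N)=N/O)cc2)O1` gives 97400 nM in an ADME assay on cells (Peritoneal macrophage, Mus musculus, strain Balb/c) for cytotoxicity, read by resazurin assay, with a stated time of 72 h; on this read-out lower numbers stand for higher toxicity in this test and higher numbers for lower toxicity in this test. Compound 2 `COc1ccc(CC2(C)CC(S(=O)(=O)c3ccc(F)cc3)=C(c3ccc(/C(N)=N/O)cc3)O2)cc1` reaches only the limit of this assay, > 100000 nM. Compound 3 `Cc1ccc(CC2(C)CC(S(=O)(=O)c3ccc(F)cc3)=C(c3ccc(/C(N)=N/O)cc3)O2)cc1` gives 54400 nM in this assay; its nearest neighbour among the plain numbers is compound 1, and a 1.8-fold lower number from compound 1 to compound 3 (0.25 log units; within the scatter) lies within the scatter, so the two cannot be ordered. Likewise an at least 1.0-fold higher number from compound 1 to compound 2 (0.01 log units; that floor lies within the scatter) and an at least 1.8-fold lower number from compound 2 to compound 3 (0.26 log units; that floor lies within the scatter) stay within the scatter. Compound 4 `CC1(/C=C/c2ccc(C(F)(F)F)cc2)CC(S(=O)(=O)c2ccc(F)cc2)=C(c2ccc(/C(N)=N/O)cc2)O1` brings (2-(4-(trifluoromethyl)phenyl)ethenyl in place of 4-methylbenzyl on a saturated ring carbon). Going by the values given here, no measured step touches that part of the core; all three concern the aromatic substituent, and none leaves the scatter. The step is therefore expected to stay within the scatter, a 1.0-fold higher number from compound 3 to compound 4 (0.00 log units; within the scatter). Compound 4 is estimated at 55000 nM, within 25000 nM to 120000 nM.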

Compound 4, half-maximal cytotoxic concentration: 43900 nM
Compound 4: the middle estimate sits 1.3-fold (0.10 log units) above what was measured; measured number inside the range.
By their numbers in this assay, from the lowest: compounds 4, 3 and 1 (each within the scatter of the next, the first and the last beyond it). At a limit, above all of these: compound 2.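

The saturated ring carbon next to the ring oxygen tolerates this exchange with little shift against the 4-methylbenzyl group, a 1.2-fold lower number from compound 3 to compound 4 (0.09 log units; within the scatter). Against the 4-nitrobenzyl group, the same position gives the first plain step beyond the scatter, a 2.2-fold lower number from compound 1 to compound 4 (0.35 log units; beyond the scatter). The step against the 4-methoxybenzyl group, an at least 2.2-fold lower number from compound 2 to compound 4 (0.35 log units; beyond the scatter), is only a floor because compound 2 stands at a limit: the limit of > 100000 nM in this assay, at which 1 of the 4 values shown sits.

The compounds shown do not separate the contribution of the ethenyl link from that of the trifluoromethyl group. Going by these compounds, how an amine or a carboxylic acid at this saturated ring carbon would read in this assay remains open.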